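This account rests on a few compounds, and the source may have more. Where it says the series, first, only, none or still open, it means among the compounds named here.

Going by the values given here, compound 3 `CC(C)C[C@H](NC(=O)c1ccncc1)C(=O)N[C@H]1CCN(Cc2ccc(OCCCN(C)C)cc2)C1` gives the only number in an assay on HEK293 cells for binding affinity to Urotensin-2 receptor (Homo sapiens), read by radioligand binding (a higher number here means a weaker inhibitor, a lower number a stronger inhibitor), namely 2000 nM. Compound 1 `COc1ccc(C(=O)N[C@H]2CCN(Cc3ccc(OCCCN(C)C)cc3)C2)cc1OC` sits at a limit of this assay, < 10000 nM. Compound 2 `Cc1ccc(C(=O)N[C@H]2CCN(Cc3ccc(OCCCN(C)C)cc3)C2)cc1C` also sits at a limit of this assay, < 10000 nM. The step that the two limits leave unreadable from compound 1 to compound 2 is accordingly not readable, which the limit of < 10000 nM in this assay, at which 2 of the 3 values shown sit, records. Compound 4 `CC(=O)N[C@@H](CC(C)C)C(=O)N[C@H]1CCN(Cc2ccc(OCCCN(C)C)cc2)C1` differs from compound 3 by methyl in place of pyridin-4-yl on a carbonyl carbon. Among the compounds with values here, no measured step touches this position, and the one step recorded on a carbonyl substituent, a step that the two limits leave unreadable from compound 1 to compound 2, carries no size, so the expectation rests on compound 3 alone with wide uncertainty. For compound 4 in this assay a step of a 2.5-fold higher number from compound 3 to compound 4 (0.40 log units; beyond the scatter) towards weaker binding is expected, beyond the scatter. Compound 4 is estimated at 5000 nM, with a range from 1500 nM to 20000 nM.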

Compound 4, inhibition constant: 2510 nM
Beside the measured number, compound 4's estimate is 2.0-fold (0.30 log units) above it, and the stated range covers the measured number.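

Replacing pyridin-4-yl with methyl on a carbonyl carbon gives, in this assay, a 1.3-fold higher number from compound 3 to compound 4 (0.10 log units; within the scatter). Going by these compounds alone, this is the first readable step at this position: the aromatic ring can go without moving the number beyond the scatter, so (pyridin-4-yl)carbonyl and acetyl are not told apart here. The steps to compound 4 from compound 1 and compound 2 cannot be read: the limit of < 10000 nM in this assay, at which 2 of the 4 values shown sit.

Open, as far as these compounds go, is whether a longer chain, an amine or a carboxylic acid on this carbonyl carbon would shift the number beyond the scatter in either direction.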